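Swapping the Group on One Nitrogen

This account rests on a few compounds, and the source may have more. Where it says the series, first, only, none or still open, it means among the compounds named here.

In a functional assay on PC-3 cells (Homo sapiens) for antiproliferative activity, read by sulforhodamine B assay, with a stated time of 72 h (on this read-out lower numbers stand for stronger inhibition and higher numbers for weaker inhibition), compound 1 (`COc1ncc(-c2ccc3ncc(NCc4ccc(C(F)(F)F)cc4)c(OC)c3c2)cc1NS(=O)(=O)c1ccc(F)cc1F`) gives 2880 nM and compound 2 (`COc1ncc(-c2ccc3ncc(NC(=O)CN4CCN(C)CC4)c(OC)c3c2)cc1NS(=O)(=O)c1ccc(F)cc1F`) gives 1730 nM as its reading. For the measured compounds named here, these are the only two numbers so far, and they lie within the usual scatter of each other. Compound 3 (`COc1ncc(-c2ccc3ncc(NCC4CCN(C(C)=O)CC4)c(OC)c3c2)cc1NS(=O)(=O)c1ccc(F)cc1F`) has not yet been measured. Its difference from compound 2 is (1-acetylpiperidin-4-yl)methyl in place of ((4-methylpiperazin-1-yl)methyl)carbonyl on a nitrogen on an aromatic ring and it lies in one place, with (1-acetylpiperidin-4-yl)methyl in place of ((4-methylpiperazin-1-yl)methyl)carbonyl on a nitrogen on an aromatic ring. One measured step changes the group on that same nitrogen, a 1.7-fold lower number from compound 1 to compound 2 (0.22 log units; within the scatter) and it stays within the scatter. Two compounds are a thin basis, but no shift beyond the scatter is expected, and a 1.3-fold higher number from compound 2 to compound 3 (0.10 log units; within the scatter) is the estimated size. Compound 3 is therefore estimated at 2200 nM in a range from 800 nM to 5500 nM on this evidence.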

Compound 3, half-maximal inhibitory concentration: 2570 nM
For compound 3 the middle estimate is 1.2-fold (0.07 log units) below the measured one, within the range that was stated.
By their numbers in this assay, from the lowest: compounds 2, 3 and 1 (each within the scatter of the next).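

In this assay the group on this nitrogen can now be compared three ways, with a 1.5-fold higher number from compound 2 to compound 3 (0.17 log units; within the scatter) and with a 1.1-fold lower number from compound 1 to compound 3 (0.05 log units; within the scatter) and none of the three readings stands apart from the others. (1-Acetylpiperidin-4-yl)methyl has as many heavy atoms as ((4-methylpiperazin-1-yl)methyl)carbonyl but fewer hydrogen-bond acceptors, and this swap, like the change from 4-(trifluoromethyl)phenyl to 1-acetylpiperidin-4-yl, leaves the reading within the scatter. Nothing measured here accounts for how close these readings lie.

The compounds shown leave open whether a free primary amine or a carboxylic acid at the end of a longer chain on this nitrogen would give a reading outside the scatter. They also leave open what a plain amino group, carrying none of these substituents, would give.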